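The source may hold more compounds than are shown below. What is called first, only, known or untested is meant among the compounds shown, and "the series" means these compounds.

Measured so far in a functional assay on HL-60 cells (Homo sapiens) for inhibition; a higher number here means a weaker inhibitor, a lower number a stronger inhibitor:
compound 1, `CC1OC(OC2CCCCC2OC(=O)NCCC(C(=O)O)C(=O)O)C(O)C(O)C1O`: 3500000 nM
compound 2, `CC1OC(OC2CCCCC2OC(=O)NCCCC(C(=O)O)C(=O)O)C(O)C(O)C1O`: 700000 nM

Compound 2 has the lowest of the two numbers in this assay; its nearest neighbour is compound 1, and the step between them is a 5.0-fold lower number from compound 1 to compound 2 (0.70 log units; beyond the scatter). That step is the only one in the series, and it is a chain extension of the same kind as the one now under consideration, sitting two bonds along the chain from the amide-type nitrogen rather than three.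

Compound 3, `CC1OC(OC2CCCCC2OC(=O)NCCCCC(C(=O)O)C(=O)O)C(O)C(O)C1O`, is not yet measured. Relative to compound 2 the difference is 2,2-dicarboxyethyl in place of dicarboxymethyl on a saturated chain carbon, three bonds along the chain from an amide-type nitrogen.

For the measured compounds named here, the one comparable step lowered the number by a modest amount beyond the scatter. Whether a second extension continues in the same direction cannot be read from a single pair, so the expectation is a lowering of similar or smaller size, with wide uncertainty either way. The step from compound 2 to compound 3 is estimated as a 2.3-fold lower number from compound 2 to compound 3 (0.37 log units; beyond the scatter). Compound 3 is accordingly expected at 300000 nM, with a range from 90000 nM to 1400000 nM in this assay.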

Compound 3, half-maximal inhibitory concentration: 4500000 nM
The estimate for compound 3 lay 15-fold (1.18 log units) below the measured number, and the stated range ends below it.
By their numbers in this assay, from the lowest: compound 2; then compounds 1 and 3 (each within the scatter of the next).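

In this assay, for the compounds shown here, the effect of lengthening the chain at this position does not carry on in one direction: the only earlier step (a 5.0-fold lower number from compound 1 to compound 2 (0.70 log units; beyond the scatter)) is reversed by the new one (a 6.4-fold higher number from compound 2 to compound 3 (0.81 log units; beyond the scatter)). The shortest and longest chains in the series are not separated (a 1.3-fold higher number from compound 1 to compound 3 (0.11 log units; within the scatter)), so the three compounds form a dip at compound 2 rather than a trend, and compound 2 is the strongest inhibitor of the three by steps beyond the scatter to both others. No supporting data accompany these numbers that would account for the reversal.

Still open, from the compounds shown here alone, is whether a longer chain, such as one ending in 4,4-dicarboxybutyl, would stay level with compound 1 and compound 3 or move the number again. Also open, going by these compounds, is whether the dip at compound 2 depends on the pair of carboxylic acids, which a chain of the same length carrying a single carboxylic acid, or an amine in their place, would test.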